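Benzyl for tert-butyl on the sulfur of compound 2

The source may report more compounds than this note shows. Statements on the series, on what has been measured and on what is new or still open speak of the compounds shown alone.

Measured so far:
compound 1, `COC(=O)N[C@@H](CSC)C(=O)N1CCC[C@H]1c1ncc(-c2ccc(-c3ccc(-c4cnc([C@@H]5CCCN5C(=O)[C@@H](NC(=O)OC)C(C)C)[nH]4)cc3)cc2)[nH]1`: 18000 nM
compound 2, `COC(=O)N[C@@H](CSC(C)(C)C)C(=O)N1CCC[C@H]1c1ncc(-c2ccc(-c3ccc(-c4cnc([C@@H]5CCCN5C(=O)[C@@H](NC(=O)OC)C(C)C)[nH]4)cc3)cc2)[nH]1`: 39000 nM

In an ADME assay on Vero cells (Chlorocebus sabaeus) for cytotoxicity (on this read-out higher numbers stand for lower toxicity in this test and lower numbers for higher toxicity in this test), compound 2 gives the higher of the two numbers; compound 1 gives the lower. Among the measured compounds shown here, the single measured step, a 2.2-fold higher number from compound 1 to compound 2 (0.34 log units; beyond the scatter), went with a larger group on the sulfur. Compound 3, `COC(=O)N[C@@H](CSCc1ccccc1)C(=O)N1CCC[C@H]1c1ncc(-c2ccc(-c3ccc(-c4cnc([C@@H]5CCCN5C(=O)[C@@H](NC(=O)OC)C(C)C)[nH]4)cc3)cc2)[nH]1`, carries benzyl in place of tert-butyl on a sulfur. For the measured compounds named here, that step also enlarges the group, but no measured step covers a ring entering here, so only a small change is expected: a 1.3-fold lower number from compound 2 to compound 3 (0.11 log units; within the scatter). Compound 3 is therefore estimated at 30000 nM in this assay, between 15000 nM and 60000 nM.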

Compound 3, half-maximal cytotoxic concentration: > 100000 nM
Compound 3: no number, only a limit; the forecaster's own chance of this, stated with the estimate: 10%; at least 3.3-fold (0.52 log units) between middle value and limit.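

In this assay, the change to benzyl on the sulfur gives an at least 2.5-fold higher number from compound 2 to compound 3 (0.40 log units; beyond the scatter), and the same group gives an at least 5.5-fold higher number from compound 1 to compound 3 (0.74 log units; beyond the scatter), so a six-membered aromatic ring at this place goes with a higher number, not a lower one. Compound 3 stands at > 100000 nM, which is a limit of the assay and not a number. How far either step really reaches therefore cannot be read: the limit of > 100000 nM in this assay, at which 1 of the 3 values shown sits.

As far as these compounds go, whether the ring itself matters or only the larger group remains open. So does whether an amine or a carboxylic acid on the phenyl ring, or a longer chain on the sulfur, would keep the read-out this high.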